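Permeability notes: methoxy on the pendant phenyl

The compounds below may be only part of what the source reports. "The series", "measured", "known", "first", "only" and "open" are said of these compounds alone.

Measured so far:
compound 1 `COc1ccc(F)cc1CNCCCNc1ccnc2cc(Cc3ccc(C#N)cc3)ccc12`: 23 10^-6 cm/s
compound 2 `COc1ccc(F)cc1CNCCCNc1ccnc2cc(-c3ccc(F)cc3)ccc12`: 237 10^-6 cm/s
compound 3 `COc1ccc(F)cc1CNCCCNc1ccnc2cc(-c3ccccc3)ccc12`: 237 10^-6 cm/s

All three numbers come from an ADME assay for permeability, using PAMPA, with a stated time of 30 min, at pH 7.4; a lower number here means that the compound crosses the layer more slowly, a higher number that the compound crosses the layer faster. Compound 3 stands level with compound 2, no change at the digits printed from compound 2 to compound 3 (within the scatter), and the pair sit well clear of compound 1, a 10-fold higher number from compound 1 to compound 3 (1.01 log units; beyond the scatter) and a 10-fold higher number from compound 1 to compound 2 (1.01 log units; beyond the scatter). Within the data shown here, the large steps both belong to the swap of the 4-cyanobenzyl group for a directly attached phenyl or 4-fluorophenyl; the only step that alters a substituent on that phenyl, hydrogen in place of fluoro, stays within the scatter.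

Compound 4 `COc1ccc(-c2ccc3c(NCCCNCc4cc(F)ccc4OC)ccnc3c2)cc1` is the next member. Its difference from compound 3: methoxy in place of hydrogen on an aromatic carbon. Among the measured compounds shown here, this is a small change of the same kind as the fluoro-to-hydrogen step, which did not move this assay beyond the scatter; no measured step adds a methoxy anywhere, so there is no direct precedent. The expectation is therefore a step of no more than scatter size, if anything a slight lowering, a 1.2-fold lower number from compound 3 to compound 4 (0.10 log units; within the scatter). Compound 4 is accordingly estimated at 190 10^-6 cm/s, with a range from 95 10^-6 cm/s to 320 10^-6 cm/s.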

Compound 4, apparent permeability: 237 10^-6 cm/s
Estimate against measurement, compound 4: 1.2-fold (0.10 log units) below, within the range that was stated.
By their numbers in this assay, from the lowest: compound 1; then compounds 2, 3 and 4 (each within the scatter of the next).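

On an aromatic carbon para to a large group, the series now holds hydrogen, fluoro and methoxy. In this assay, the methoxy compound gives no change at the digits printed from compound 3 to compound 4 (within the scatter) and no change at the digits printed from compound 2 to compound 4 (within the scatter), so the flat reading at this position now extends beyond the hydrogen and fluoro pair to a group with 2 heavy atoms and 1 hydrogen-bond acceptor. The large step away from the 4-cyanobenzyl group also recurs with a third directly attached ring, a 10-fold higher number from compound 1 to compound 4 (1.01 log units; beyond the scatter), and no compound shown goes against it. Nothing at hand bears on the reason for either reading.

From the compounds shown here alone, whether the reading holds with an amine or a carboxylic acid at this position stays open, as does its behaviour with a longer chain such as butoxy in place of methoxy. Also open, going by these compounds, is how the large step divides between the methylene link and the nitrile, both of which compound 1 carries; a plain benzyl group and a 4-cyanophenyl group would separate the two.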